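The compounds below may be only part of what the source reports. "The series", "measured", "known", "first", "only" and "open" are said of these compounds alone.

Working notes on the series, cytotoxicity on mouse macrophages.

Of the compounds shown here, three have numbers so far. Compound 1 `CCOC(=O)c1sc(-c2ccccn2)nc1N1CCC(NCc2ccccc2)CC1` gives 14.6% in an ADME assay on RAW264.7 cells (Mus musculus) for cytotoxicity, read by MTT assay, with a stated time of 72 h, tested at 50 uM; a lower number here means less inhibition, a higher number more inhibition at the concentration tested (going by the name of the read-out). Compound 2 `CCOC(=O)c1sc(-c2ccccn2)nc1N1CCC(NCc2ccc(F)cc2)CC1` gives 12.6% in this assay. Compound 3 `CCOC(=O)c1sc(-c2ccccn2)nc1N1CCC(NCc2ccc(C(F)(F)F)cc2)CC1` gives 14.6% in this assay. All three carry the same core and differ only in what sits on the aromatic ring of the benzyl group: a number 2 percentage points lower from compound 1 to compound 2 (within the scatter), no change at the digits printed from compound 1 to compound 3 (within the scatter) and a number 2 percentage points higher from compound 2 to compound 3 (within the scatter). Every one of these steps lies within the scatter, so the three numbers cannot be told apart. Compound 3 is level with compound 1 at the digits shown, and compound 2 lies within the scatter of both.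

Compound 4 `CCOC(=O)c1sc(-c2ccccn2)nc1N1CCC(NCc2ccc(Cl)c(Cl)c2)CC1` is the next member. Relative to compound 3 the change is 3,4-dichlorophenyl in place of 4-(trifluoromethyl)phenyl on a saturated chain carbon bound to an amine nitrogen. The three measured steps are the ones that bear on it, since each also exchanges what sits on that aromatic ring; none of them moved the read-out beyond the scatter. On that basis the step from compound 3 to compound 4 in this assay is expected to be a number 0.4 percentage points higher from compound 3 to compound 4 (within the scatter), that is, nothing beyond the scatter. Compound 4 is therefore estimated at 15% in this assay, with a range from 5% to 26%.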

Compound 4, a percentage reported as inhibition, at one concentration (the size of the read-out at that concentration, not a potency): 30.1%
Estimate against measurement, compound 4: 15.1 percentage points below, and the stated range ends below it.
By their numbers in this assay, from the lowest: compounds 2, 1 and 3 (each within the scatter of the next); then compound 4.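

Placing 3,4-dichlorophenyl on the saturated chain carbon bound to an amine nitrogen gives the first change in the series that lies beyond the scatter in this assay: a number 15.5 percentage points higher from compound 1 to compound 4 (beyond the scatter) against phenyl, a number 17.5 percentage points higher from compound 2 to compound 4 (beyond the scatter) against 4-fluorophenyl and a number 15.5 percentage points higher from compound 3 to compound 4 (beyond the scatter) against 4-(trifluoromethyl)phenyl. The flat picture from the first three compounds therefore holds only for those three aromatic groups, and this position can respond to what the ring carries, with compound 4 now standing apart from compounds 1, 2 and 3. Nothing available explains why this group behaves differently from the others.

Compound 4 is the only compound shown with chlorine and the only one with two substituents on the ring, so the compounds shown cannot separate the effect of chlorine from that of having two substituents, and a ring with a single chloro group would bear directly on this. Also open, from the compounds shown here alone, is how the read-out responds to quite different groups on the ring, such as methoxy, a carboxylic acid or an amine.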